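The source may hold more compounds than are shown below. What is called first, only, known or untested is meant among the compounds shown, and "the series" means these compounds.

Two compounds of a shared core carry a sulfonyl-linked aryl bearing an oxazole with a cyclopropyl group, and differ only in the substituent on the fused six-membered carbon ring. Compound 1 `Nc1ccc2c(c1)OCCCN2S(=O)(=O)c1ccc(-c2cnc(C3CC3)o2)cc1` carries an amino group there, and compound 2 `COc1ccc2c(c1)N(S(=O)(=O)c1ccc(-c3cnc(C4CC4)o3)cc1)CCCO2` carries a methoxy group at another position of that ring. In a functional assay on SK-OV-3 cells (Homo sapiens) for antiproliferative activity, read by MTT assay, with a stated time of 72 h (on this read-out higher numbers stand for weaker inhibition and lower numbers for stronger inhibition), compound 1 gives 56 nM, and in this assay compound 2 gives 53 nM. Compound 1 has the higher of the two numbers, but the gap to compound 2 is within the scatter, so the two cannot be told apart by their potency.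

Compound 3 `COc1ccc2c(c1)OCCCN2S(=O)(=O)c1ccc(-c2cnc(C3CC3)o2)cc1` is not yet measured. It differs from compound 1 by a single change, (methoxy in place of amino on an aromatic carbon). No comparison of two measured compounds isolates exactly this exchange. What the data show is that a methoxy group elsewhere on the same ring, in compound 2, sits at a value close to that of compound 1, which gives no sign of a large shift. The step from compound 1 to compound 3 is therefore expected to stay within the scatter, in either direction, at a 1.0-fold lower number from compound 1 to compound 3 (0.01 log units; within the scatter). Compound 3 is estimated at 55 nM, with a likely range from 25 nM to 120 nM.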

Compound 3, half-maximal inhibitory concentration: 185 nM
Compound 3: middle estimate off by 3.4-fold (0.53 log units), on the low side; the measured number lies above the stated range.
By their numbers in this assay, from the lowest: compounds 2 and 1 (each within the scatter of the next); then compound 3.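

In this assay, placing methoxy where compound 1 carries amino gives a 3.3-fold higher number from compound 1 to compound 3 (0.52 log units; beyond the scatter), a modest weakening of inhibition that lies beyond the usual scatter. This position on the aromatic ring therefore responds to the group it carries, which the close values of compound 1 and compound 2 could not reveal. The methoxy group also does not give one fixed result on this ring: with the group placed elsewhere, compound 2 gives 53 nM, whereas compound 3 gives 185 nM, so where it sits appears to matter as well as what it is.

Nothing available here explains why the number rises with this exchange. Still open, from the compounds shown here alone, is how other groups at this same position would compare with amino and methoxy, for example a hydroxyl group, a dimethylamino group or a longer ethoxy chain, and whether any of them would keep the number close to that of compound 1.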